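Adding a methoxy group to the carboxyphenyl amide

The compounds below may be only part of what the source reports. "The series", "measured", "known", "first", "only" and "open" are said of these compounds alone.

In a functional assay on RKO cells (Homo sapiens) for inhibition, read by MTT assay (a lower number here means a stronger inhibitor, a higher number a weaker inhibitor), compound 1 `CC(C)(C)C[C@@H]1N[C@@H](C(=O)Nc2ccn(CC(C)(C)O)n2)[C@H](c2cccc(Cl)c2F)[C@@]1(C#N)c1ccc(Cl)cc1F` gives 1420 nM while compound 2 `CC(C)(C)C[C@@H]1N[C@@H](C(=O)Nc2ccc(C(=O)O)cc2)[C@H](c2cccc(Cl)c2F)[C@@]1(C#N)c1ccc(Cl)cc1F` gives 210 nM as the lower of the two numbers. Compound 3 `COc1cc(NC(=O)[C@@H]2N[C@@H](CC(C)(C)C)[C@](C#N)(c3ccc(Cl)cc3F)[C@H]2c2cccc(Cl)c2F)ccc1C(=O)O` carries methoxy in place of hydrogen on an aromatic carbon ortho to a carboxy group, turning 4-carboxyphenyl to 4-carboxy-3-methoxyphenyl. For the measured compounds named here, the only measured step of a 6.8-fold lower number from compound 1 to compound 2 (0.83 log units; beyond the scatter) exchanged the entire group on the amide-type nitrogen, so it says little about so small an addition. The expected change a 1.1-fold higher number from compound 2 to compound 3 (0.06 log units; within the scatter) is small in this assay and may not exceed the scatter. Compound 3 is estimated at 240 nM with an expected range of 100 nM to 580 nM in this measurement.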

Compound 3, half-maximal inhibitory concentration: 140 nM
The estimate for compound 3 lay 1.7-fold (0.23 log units) above the measured number; the range from low to high includes it.
By their numbers in this assay, from the lowest: compounds 3 and 2 (each within the scatter of the next); then compound 1.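

In this assay, the step of a 1.5-fold lower number from compound 2 to compound 3 (0.18 log units; within the scatter) shows that this position on the ring accepts methoxy in place of hydrogen without a change beyond the scatter. The exchange of the whole group on the amide-type nitrogen still stands out, with a 10-fold lower number from compound 1 to compound 3 (1.01 log units; beyond the scatter) for the methoxy compound. No measurement here offers an explanation for either step. Going by these compounds, whether a larger ethoxy group or a small fluorine would be accepted at this same position remains open. So does the outcome of replacing the carboxy group with a primary amide.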